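Swapping the aminophenyl of compound 1 for a dichlorophenyl

The compounds below may be only part of what the source reports. "The series", "measured", "known", "first", "only" and "open" are said of these compounds alone.

Measured so far:
compound 1, `COc1cc(-c2cc(/C=C/C(=O)c3ccc(N)cc3)[nH]n2)cc(OC)c1OC` — -55%
compound 2, `COc1ccc(-c2cc(/C=C/C(=O)c3ccc(OC)c(OC)c3)[nH]n2)cc1` — -73%

In a functional assay on NCI-H23 cells (Homo sapiens) for cytotoxicity, read by sulforhodamine B assay, with a stated time of 48 h, tested at 100 uM (on this read-out lower numbers stand for a stronger effect and higher numbers for a weaker effect at the one concentration tested), compound 1 gives -55%, the higher, and therefore weaker, of the two numbers; compound 2 gives -73%, a reading beyond the usual scatter below it. Compound 3, `COc1cc(-c2cc(/C=C/C(=O)c3ccc(Cl)c(Cl)c3)[nH]n2)cc(OC)c1OC`, has not been measured. It differs from compound 1 in one place: 3,4-dichlorophenyl in place of 4-aminophenyl on a carbonyl carbon. Among the compounds with values here, no pair of measured compounds shows a change of this kind, so its size cannot be read from the data. A step of modest size, with no firm direction, is expected from compound 1 to compound 3 a number 5 percentage points lower from compound 1 to compound 3 (within the scatter). For compound 3 the expected value in this assay is -60%, within -85% to -35%.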

Compound 3, a percentage reported as activity, at one concentration (the size of the read-out at that concentration, not a potency): 5%
Beside the measured number, compound 3's estimate is 65 percentage points below it, and the stated range ends below it.
By their numbers in this assay, from the lowest: compound 2; then compound 1; then compound 3.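

On the carbonyl carbon, the group carried matters strongly in this assay: with the rest of the molecule unchanged, 3,4-dichlorophenyl in place of 4-aminophenyl gives a number 60 percentage points higher from compound 1 to compound 3 (beyond the scatter), a large loss of effect. Within the data shown here, this is the first view of a single change at this place, and the earlier pair, which differs in more than one place, could not show it. Nothing available explains the size of this step.

As far as these compounds go, whether the loss comes from losing the amine or from gaining the two chlorines remains open. A plain phenyl or a 4-chlorophenyl on this carbonyl carbon would help separate the two.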